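Swapping phenyl for methyl on a sigma-receptor ligand core

A few compounds are considered here, and "the series" means these few. Any claim that something is new, unique, unknown or untested is made for them only; others in the source may bear on it.

Measured compounds:
- compound 1, `COC1Cc2c(cnn2-c2ccccc2)C2(CCN(CCCc3ccccc3)CC2)O1`: 3.2 nM
- compound 2, `COC1Cc2c(cnn2C)C2(CCN(CCCc3ccccc3)CC2)O1`: 93 nM
- compound 3, `C1=Cc2c(cnn2-c2ccccc2)C2(CCN(Cc3ccccc3)CC2)O1`: 1.48 nM

All three were tested in an assay for displacement of a labelled ligand from Sigma non-opioid intracellular receptor 1 (Cavia porcellus), read by scintillation counting, with a stated time of 180 min; on this read-out higher numbers stand for weaker inhibition and lower numbers for stronger inhibition. Compound 1 and compound 2 share one core and differ in a single place: methyl in place of phenyl on an aromatic nitrogen. That change produced a 29-fold higher number from compound 1 to compound 2 (1.46 log units; beyond the scatter), so the methyl analogue binds much more weakly than its phenyl parent.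

Compound 3 has the lowest number of the three. Compared with compound 1, compound 3 gives a number lower by a margin that is beyond the usual scatter, and compound 2 is further away still. The difference between the core of compound 3 and the core of compound 1 is not broken down here.

Compound 4, `Cn1ncc2c1C=COC21CCN(Cc2ccccc2)CC1`, has not yet been measured. It is related to compound 3 in exactly the way compound 2 is related to compound 1: methyl in place of phenyl on an aromatic nitrogen. For the measured compounds named here, since this is the same change at the same place, the step seen from compound 1 to compound 2 is the only guide, though the two cores differ, so the size may not carry over exactly. Compound 4 is therefore expected to show a weaker binding, with a step of about a 27-fold higher number from compound 3 to compound 4 (1.43 log units; beyond the scatter) in this assay, because of a 29-fold higher number from compound 1 to compound 2 (1.46 log units; beyond the scatter). On that basis the estimated value for compound 4 is 40 nM, with a likely range from 10 nM to 160 nM.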

Compound 4, inhibition constant: 12 nM
Estimate against measurement, compound 4: 3.3-fold (0.52 log units) above; the range from low to high includes it.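

Putting methyl in place of phenyl on the aromatic nitrogen again gives weaker binding in this assay, with an 8.1-fold higher number from compound 3 to compound 4 (0.91 log units; beyond the scatter), so the direction of the change is the same in both pairs. The size of the change is not the same, and the gap between the two steps is larger than repeated measurements would explain: the same change on two cores in this assay, a 29-fold higher number (1.46 log units; beyond the scatter) from compound 1 to compound 2 and an 8.1-fold higher number (0.91 log units; beyond the scatter) from compound 3 to compound 4, 3.6-fold (0.55 log units) apart, beyond the scatter of two such steps These two pairs show that the step on one core gave the right direction on the other but not a dependable size, and they do not show what sets the size, as the core of compound 1 and the core of compound 3 differ in more than one place.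

The compounds shown leave open how binding responds to other groups on the same aromatic nitrogen, such as an ethyl group or a cyclohexyl ring, which would show whether the loss tracks the size of the group or the presence of an aromatic ring. Also open, from the compounds shown here alone, is which difference between the two cores changes the size of the step, a question that only compounds differing in one place at a time could settle.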